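Swapping One Ring Arm on Two Adrenergic Agonists

The compounds below may be only part of what the source reports. "The series", "measured", "known", "first", "only" and "open" are said of these compounds alone.

Compound 1, `c1ccc(-c2ccno2)c(OCC2=NCCN2)c1`: 91%
Compound 2, `c1ccc(-c2ccno2)c(OCc2c[nH]cn2)c1`: 91%
Compound 3, `c1ccc(N2CCCCC2)c(NCC2=NCCN2)c1`: 114%

All three compounds were tested in a functional assay for activation of Alpha-1A adrenergic receptor (Homo sapiens); on this read-out lower numbers stand for smaller maximal responses and higher numbers for larger maximal responses. Compound 1 and compound 2 share a core and differ in one place only: a group of 5 heavy atoms (3 carbon, 2 nitrogen; one five-membered aromatic ring with 2 hetero atoms) in place of a group of 5 heavy atoms (3 carbon, 2 nitrogen; one five-membered non-aromatic ring with 2 hetero atoms), on a saturated chain carbon bound to an oxygen on an aromatic ring. This swap left the read-out where it was, no change at the digits printed from compound 1 to compound 2 (within the scatter). Compound 3 is built on a different core; the difference between the two cores is not broken down here. Compound 3 gives the highest of the three numbers, and its distance from each of the other two lies beyond the scatter.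

Compound 4, `c1ccc(N2CCCCC2)c(NCc2c[nH]cn2)c1`, has not yet been measured. It differs from compound 3 by a group of 5 heavy atoms (3 carbon, 2 nitrogen; one five-membered aromatic ring with 2 hetero atoms) in place of a group of 5 heavy atoms (3 carbon, 2 nitrogen; one five-membered non-aromatic ring with 2 hetero atoms), on a saturated chain carbon bound to a nitrogen on an aromatic ring. Among the measured compounds shown here, this is the same kind of change as the one between compound 1 and compound 2, but not the same: there the ring arm sat on a saturated chain carbon bound to an oxygen on an aromatic ring, here it sits on a saturated chain carbon bound to a nitrogen on an aromatic ring. Because the matching step gave no change at the digits printed from compound 1 to compound 2 (within the scatter), the step from compound 3 to compound 4 is expected to be small, a number 4 percentage points lower from compound 3 to compound 4 (within the scatter). Compound 4 is therefore estimated at 110%, between 90% and 130%.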

Compound 4, largest response reached (reported as maximum), in percent of the reference or control that the assay uses: 95%
Compound 4: the middle estimate sits 15 percentage points above what was measured, within the range that was stated.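

In this assay, putting 1H-imidazol-4-yl in place of the five-membered non-aromatic ring on the core of compound 3 gives a number 19 percentage points lower from compound 3 to compound 4 (beyond the scatter). This swap therefore does not carry over unchanged from one core to the other, and a step read on one core proved a poor guide to the step on the other: the same change on two cores in this assay, no change at the digits printed (within the scatter) from compound 1 to compound 2 and a number 19 percentage points lower (beyond the scatter) from compound 3 to compound 4, 19 percentage points apart, beyond the scatter of two such steps. These two pairs do not show which part of the core decides the size of the step, and they say nothing about how the same swap would behave on any third core.

The compounds shown leave open whether another arm, such as a simple primary amine or an open-chain amidine, would give the same result on both cores. They also leave open whether a longer chain in place of the single saturated chain carbon would make the two steps grow closer together or further apart.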